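A larger side chain on a piperidine

The source may report more compounds than this note shows. Statements on the series, on what has been measured and on what is new or still open speak of the compounds shown alone.

In an ADME assay on microsomes from liver (Homo sapiens) for metabolic stability, read by LC-MS, tested at 1 uM (a higher number here means faster removal of the compound, a lower number slower removal), compound 1 `NCCOCCOc1ccc([C@H]2CC[C@]3(CC2)OOC2(O3)C3CC4CC(C3)CC2C4)cc1` gives < 7 mL.min-1.g-1 as its result, and this is a limit of the assay rather than a number.

For the measured compounds named here, compound 2 `OC1(COc2ccc([C@H]3CC[C@]4(CC3)OOC3(O4)C4CC5CC(C4)CC3C5)cc2)CCNCC1` gives 16 mL.min-1.g-1 as the only actual number so far, so it has no measured neighbour to be ranked against.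

Compound 3 `CC(C)(O)CN1CCC(Oc2ccc([C@H]3CC[C@]4(CC3)OOC3(O4)C4CC5CC(C4)CC3C5)cc2)CC1` keeps the shared core and differs only in the group on an oxygen on an aromatic ring. The change is 1-(2-hydroxy-2-methylpropyl)piperidin-4-yl in place of (4-hydroxypiperidin-4-yl)methyl on an oxygen on an aromatic ring and both groups hold one six-membered non-aromatic ring with 1 hetero atom.

Going by the values given here, only one measured step bears on this, namely an at least 2.2-fold higher number from compound 1 to compound 2 (0.35 log units; beyond the scatter) and it lies beyond the scatter. It shows that swapping a group in this part of the molecule can move the number, but it involves a different swap and gives no direction here.

The expectation therefore starts from compound 2 at 16 mL.min-1.g-1 and allows a wide margin on both sides.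

The expected change is a 1.3-fold higher number from compound 2 to compound 3 (0.10 log units; within the scatter) and no shift beyond the scatter is foreseen.

For compound 3 the estimated clearance is 20 mL.min-1.g-1 (expected range 8 mL.min-1.g-1 to 48 mL.min-1.g-1).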

Compound 3, intrinsic clearance in microsomes: 18 mL.min-1.g-1
For compound 3 the middle estimate is 1.1-fold (0.05 log units) above the measured one; the range from low to high includes it.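

In this assay, the swap from (4-hydroxypiperidin-4-yl)methyl to 1-(2-hydroxy-2-methylpropyl)piperidin-4-yl on the oxygen gives a 1.1-fold higher number from compound 2 to compound 3 (0.05 log units; within the scatter), so these two piperidine-containing groups cannot be told apart here, although the entering group has 11 heavy atoms against 8 and one hydrogen-bond donor instead of two. Measured against the 2-(2-aminoethoxy)ethyl chain, the new group shows an at least 2.5-fold higher number from compound 1 to compound 3 (0.41 log units; beyond the scatter), which points the same way as the step already seen with the other piperidine-containing group, an at least 2.2-fold higher number from compound 1 to compound 2 (0.35 log units; beyond the scatter). The true size of both steps stays unknown because compound 1 stands at a limit of the assay, not at a number: the limit of < 7 mL.min-1.g-1 in this assay, at which 1 of the 3 values shown sits.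

The compounds shown leave open whether the piperidine ring or the groups attached to it go with the higher numbers seen for compound 2 and compound 3 compared with compound 1. A plain piperidin-4-yl group, or a morpholine ring in place of the piperidine, would help to separate these two parts.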